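Swapping halogen positions on the anilide of compound 3

This account rests on a few compounds, and the source may have more. Where it says the series, first, only, none or still open, it means among the compounds named here.

Of the compounds shown here, three have been tested in an ADME assay on MT2 cells (Homo sapiens) for cytotoxicity, read by XTT assay, with a stated time of 4 days; a higher number here means that more compound is tolerated, a lower number that less compound is tolerated. Compound 1 `CC(=O)N1CCCCC1C(NC(=O)C(=O)Nc1ccc(Cl)cc1)c1nc(C)c(CCO)s1` gives > 84000 nM in this assay, which is a limit of the assay and not a number, (the limit of > 84000 nM in this assay, at which 1 of the 3 values shown sits). Compound 2 `Cc1nc(C(NC(=O)C(=O)Nc2ccc(Cl)cc2)C2CCCN2)sc1CO` gives 45000 nM. Compound 3 `Cc1nc(C(NC(=O)C(=O)Nc2ccc(Cl)c(F)c2)C2CCCCN2)sc1CO` gives 77800 nM in this assay, the higher of the two numbers, though its gap to compound 2 lies within the scatter, so no order between them can be claimed.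

Compound 4 `Cc1nc(C(NC(=O)C(=O)Nc2ccc(F)c(Cl)c2)C2CCCCN2)sc1CO` differs from compound 3 in one respect: 3-chloro-4-fluorophenyl in place of 4-chloro-3-fluorophenyl on an amide-type nitrogen. The same atoms are present in both; only the arrangement of the chlorine and fluorine on the ring changes. Going by the values given here, no measured pair in this set shows what such a swap does in this assay, so there is no precedent to lean on.

Compound 4 is therefore expected to give 70000 nM in this assay, estimated to lie between 35000 nM and 140000 nM. This estimate means a step of a 1.1-fold lower number from compound 3 to compound 4 (0.05 log units; within the scatter), expected to stay within the scatter of repeated measurements, with a fair chance that the assay again reports only a limit.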

Compound 4, half-maximal cytotoxic concentration: > 77800 nM
Compound 4 ended at the assay's limit (the forecaster's own chance of this, stated with the estimate: 40%); at least 1.1-fold (0.04 log units) between middle value and limit.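

In this assay, placing 3-chloro-4-fluorophenyl where compound 3 carries 4-chloro-3-fluorophenyl on an amide-type nitrogen gives a number no lower from compound 3 to compound 4 (the limit leaves the size open). Going by these compounds alone, this is the first pair in the set that differs in one place, and it shows that rearranging the same two halogens on this ring brings no drop in the tolerated concentration. The value of compound 4 is a limit of the assay and not a number: the limit of > 77800 nM in this assay, at which 1 of the 4 values shown sits.

The compounds shown leave open how far the true value of compound 4 lies from that of compound 3, so the size of this step stays unknown. They also leave open what a different group at this place, such as 3,4-dichlorophenyl or 4-methoxyphenyl, would give in this assay.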